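This account rests on a few compounds, and the source may have more. Where it says the series, first, only, none or still open, it means among the compounds named here.

Compound 1, whose structure is `Cc1nc(NCCNS(C)(=O)=O)nc2ccc(NC(=O)/C=C/c3ccc(OC(F)(F)F)cc3)cc12`, is the starting point of this account. In a functional assay on CHO-K1 cells for antagonist activity at melanin-concentrating hormone receptor 1 (Homo sapiens), read by inositol phosphate accumulation, with stated times of 10 min and 45 min (a lower number here means a stronger inhibitor, a higher number a weaker inhibitor), compound 1 gives 142 nM, the lowest of the three numbers available. Compound 2, with structure `C/C(=C\C(=O)Nc1ccc2nc(N3CCC(O)(C4CC4)CC3)nc(C)c2c1)c1ccc(Cl)cc1`, gives 340 nM in this assay, and compound 3, with structure `Cc1nc(N2CCC(O)(C3CC3)CC2)nc2ccc(NC(=O)/C=C/c3ccc(Cl)cc3Cl)cc12`, gives 575 nM; the gap from compound 1 to each of them lies beyond the scatter. Among the measured compounds shown here, the single step that joins two measured compounds is a 1.7-fold higher number from compound 2 to compound 3 (0.23 log units; within the scatter), and it concerns the group on the carbonyl carbon, not the part of the core where compound 4 differs.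

Compound 4, with structure `Cc1nc(N2CCC(N3CCCC3=O)CC2)nc2ccc(NC(=O)/C=C/c3ccc(OC(F)(F)F)cc3)cc12`, is not yet measured. It differs from compound 1 by 4-(2-oxopyrrolidin-1-yl)piperidin-1-yl in place of (2-(methanesulfonamido)ethyl)amino on an aromatic carbon. For the measured compounds named here, no measured pair isolates this exchange: compounds 2 and 3 carry a cyclic amine at the same aromatic carbon while compound 1 carries the open chain, but they also differ from compound 1 on the carbonyl side, so their values speak only loosely. Their numbers sit somewhat above compound 1, and so a modest weakening is expected, with the step of a 1.5-fold higher number from compound 1 to compound 4 (0.19 log units; within the scatter) likely still close to the scatter. For compound 4 in this assay the estimate is 220 nM, within a range from 60 nM to 800 nM.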

Compound 4, half-maximal inhibitory concentration: 12 nM
Beside the measured number, compound 4's estimate is 18-fold (1.26 log units) above it; the whole stated range lies above it.
By their numbers in this assay, from the lowest: compound 4; then compound 1; then compounds 2 and 3 (each within the scatter of the next).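

In this assay, among the compounds shown here, the exchange on the aromatic carbon between two ring nitrogen atoms gives a 12-fold lower number from compound 1 to compound 4 (1.07 log units; beyond the scatter) and so shows, as no earlier pair could, that this position alone can move the number well beyond the scatter while the rest of compound 1 stays unchanged. The change replaces an open chain with no ring and 2 hydrogen-bond donors by 4-(2-oxopyrrolidin-1-yl)piperidin-1-yl, with its two non-aromatic rings and 0 hydrogen-bond donors, and the lower number belongs to this replacement as a whole, not to any one of its parts. Nothing measured here bears on why the number falls so far, so the step stands without an explanation.

The compounds shown leave open which part of the entering group carries the step, a question that a piperidin-1-yl ring bearing a plain amine or an open acetamide in place of the 2-oxopyrrolidin-1-yl group could address. Also open, as far as these compounds go, is whether 4-(2-oxopyrrolidin-1-yl)piperidin-1-yl would bring a similar step alongside the carbonyl-side groups of compound 2 and compound 3.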